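The source may hold more compounds than are shown below. What is called first, only, known or untested is meant among the compounds shown, and "the series" means these compounds.

Measured compounds:
- compound 1, `c1csc(-c2ccccc2NCC2=NCCN2)c1`: 5.75 nM
- compound 2, `Cc1cc(-c2ccccc2NCC2=NCCN2)on1`: 95.5 nM
- compound 3, `c1ccc(-c2cnoc2)c(NCC2=NCCN2)c1`: < 100000 nM

In a functional assay for activation of Alpha-1B adrenergic receptor (Homo sapiens), read by calcium flux (on this read-out higher numbers stand for an effect only at larger amounts of compound and lower numbers for an effect already at smaller amounts), compound 1 gives 5.75 nM. Compound 2 gives 95.5 nM in this assay, and the change a 17-fold higher number from compound 1 to compound 2 (1.22 log units; beyond the scatter) is a large one. For compound 3 this assay reports only a limit, < 100000 nM, so its place among the numbers is not fixed (the limit of < 100000 nM in this assay, at which 1 of the 3 values shown sits). Compound 4, `Cc1ccc(-c2ccccc2NCC2=NCCN2)o1`, differs from compound 3 by 5-methylfuran-2-yl in place of 1,2-oxazol-4-yl on an aromatic carbon. The steps that touch compound 3, a step that the limit leaves unreadable from compound 1 to compound 3 and a step that the limit leaves unreadable from compound 2 to compound 3, cannot be read for size, so they give no measure of what the change to compound 4 should bring. What remains is that compound 1, which carries thiophen-2-yl, a five-membered aromatic ring with one hetero atom, gives 5.75 nM, and compound 4 carries 5-methylfuran-2-yl, also a five-membered aromatic ring with one hetero atom. On that basis compound 4 is expected to give a number nearer to compound 1 than to the limit of compound 3, so the step that the limit leaves unreadable from compound 3 to compound 4 is expected to be toward lower numbers. Compound 4 is estimated at 20 nM, within a range from 4 nM to 150 nM.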

Compound 4, half-maximal effective concentration: 46.8 nM
Compound 4: middle estimate off by 2.3-fold (0.37 log units), on the low side; the measured number falls inside the stated range.
By their numbers in this assay, from the lowest: compound 1; then compound 4; then compound 2.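

In this assay, a five-membered aromatic ring with 1 hetero atom on this aromatic carbon, ortho to a group of 7 heavy atoms, does not by itself reproduce the number of the thiophen-2-yl ring: 5-methylfuran-2-yl brings an 8.1-fold higher number from compound 1 to compound 4 (0.91 log units; beyond the scatter). Set against the 3-methyl-1,2-oxazol-5-yl group, the same 5-methylfuran-2-yl brings a 2.0-fold lower number from compound 2 to compound 4 (0.31 log units; beyond the scatter), so the gap between these two methyl-bearing rings is far smaller than the gap to thiophen-2-yl. All steps that touch compound 3 remain unreadable, and its value is only a limit: the limit of < 100000 nM in this assay, at which 1 of the 4 values shown sits.

Still open, going by these compounds, is how much of the change from thiophen-2-yl belongs to the methyl and how much to the ring oxygen in place of sulfur. A plain furan-2-yl or a 5-methylthiophen-2-yl would separate the two, and an aminomethyl group on the ring would test a different kind of substituent.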